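Taking the chloro group off compound 1

The source may hold more compounds than are shown below. What is called first, only, known or untested is meant among the compounds shown, and "the series" means these compounds.

Compound 1 `COc1cc(OC)c(OC)cc1/C=C/C(=O)c1ccc(Cl)cc1`: 29500 nM
Compound 2 `COc1cc(OC)c(OC)cc1/C=C/C(=O)c1cc(OC(C)=O)ccc1OC(C)=O`: 63700 nM
Compound 3 `COc1cc(OC)c(-c2cc(=O)c3ccc(O)cc3o2)cc1OC`: > 150000 nM, a limit and not a number

In a functional assay on MCF7 cells (Homo sapiens) for inhibition, read by MTT assay, with a stated time of 72 h (a higher number here means a weaker inhibitor, a lower number a stronger inhibitor), compound 1 stands lowest of the two numbers at 29500 nM. Compound 2 gives 63700 nM, and the difference between these two numbers lies beyond the scatter. For compound 3, > 150000 nM is a limit.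

Compound 4 `COc1cc(OC)c(OC)cc1/C=C/C(=O)c1ccccc1` is still unmeasured. It carries hydrogen in place of chloro on an aromatic carbon, para to a large group (hydrogen in place of chloro on an aromatic carbon). Within the data shown here, no measured pair shows a single-place step, so from compound 1 at 29500 nM only a modest move toward a higher number is expected, perhaps close to the scatter. The expected change is a 1.4-fold higher number from compound 1 to compound 4 (0.13 log units; within the scatter). For compound 4 the estimate is 40000 nM, with an expected range of 15000 nM to 100000 nM.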

Compound 4, half-maximal inhibitory concentration: > 150000 nM
Compound 4 was reported as a limit; the forecaster's own chance of this, stated with the estimate: 8%; middle value at least 3.7-fold (0.57 log units) away from the limit.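

Hydrogen in place of chloro on an aromatic carbon, para to a large group, gives an at least 5.0-fold higher number from compound 1 to compound 4 (0.70 log units; beyond the scatter) in this assay, the first single-place step seen here, and it shows that activity in this series depends on the chloro group at this position. Compound 4 gives > 150000 nM, which is a limit and not a number. The step therefore sets only a lower bound on the size of the change: the limit of > 150000 nM in this assay, at which 2 of the 4 values shown sit.

The compounds shown leave open whether a bromo group, a methoxy group or an amine at this position would match the chloro group. They also leave open how far the loss truly extends.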